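The source may hold more compounds than are shown below. What is called first, only, known or untested is meant among the compounds shown, and "the series" means these compounds.

Measured in a functional assay on MCF7 cells (Homo sapiens) for cytotoxicity, read by MTT assay, with a stated time of 48 h; a higher number here means a weaker inhibitor, a lower number a stronger inhibitor:
- compound 1 `O=C1/C(=C\c2ccc(O)cc2)S/C(=N/c2ccccc2)N1Cc1ccncc1`: 18900 nM
- compound 2 `O=C1/C(=C\c2ccc(Cl)cc2)S/C(=N/c2ccccc2)N1Cc1ccncc1`: 54900 nM
- compound 3 `CCOc1cc(/C=C2/S/C(=N/c3ccccc3)N(Cc3ccncc3)C2=O)ccc1O`: 20100 nM

Compound 3 belongs to the lower pair of these numbers (the data show a 1.1-fold higher number from compound 1 to compound 3 (0.03 log units; within the scatter) and a 2.7-fold lower number from compound 2 to compound 3 (0.44 log units; beyond the scatter)). The next structure is compound 4 `COc1ccc(OC)c(/C=C2/S/C(=N/c3ccccc3)N(Cc3ccncc3)C2=O)c1`, with 2,5-dimethoxyphenyl in place of 3-ethoxy-4-hydroxyphenyl on a double-bonded chain carbon bound to a double-bonded ring carbon. Among the measured compounds shown here, no measured compound carries this group, so the guide is indirect. Compound 4 has no hydroxy on this ring, and neither has compound 2, where the data show a 2.9-fold higher number from compound 1 to compound 2 (0.46 log units; beyond the scatter) for chloro in place of hydroxy. A modest rise is therefore expected in this assay (estimated as a 1.6-fold higher number from compound 3 to compound 4 (0.20 log units; within the scatter)). The estimate for compound 4 is 32000 nM (range 14000 nM to 70000 nM).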

Compound 4, half-maximal inhibitory concentration: 37000 nM
For compound 4 the middle estimate is 1.2-fold (0.06 log units) below the measured one; the measured number falls inside the stated range.
By their numbers in this assay, from the lowest: compounds 1, 3, 4 and 2 (each within the scatter of the next, the first and the last beyond it).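

In this assay, rearranging the same atoms into 2,5-dimethoxyphenyl on this double-bonded chain carbon removes the hydrogen-bond donor and gives a 1.8-fold higher number from compound 3 to compound 4 (0.27 log units; within the scatter). Compound 4 also shows a 2.0-fold higher number from compound 1 to compound 4 (0.29 log units; within the scatter) and a 1.5-fold lower number from compound 2 to compound 4 (0.17 log units; within the scatter), so it cannot be separated from any of the three earlier compounds, even though compound 1 and compound 2 stand apart from each other. Nothing available here explains this result. Going by these compounds, whether an amine or a carboxylic acid on this ring would move the number beyond the scatter remains open.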